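The source may hold more compounds than are shown below. What is called first, only, known or untested is meant among the compounds shown, and "the series" means these compounds.

In a functional assay on K562 cells (Homo sapiens) for antiproliferative activity, read by MTT assay, with a stated time of 72 h (a higher number here means a weaker inhibitor, a lower number a stronger inhibitor), compound 1 `COc1ccc(-c2c(C(=O)c3cc(OC)c(OC)c(OC)c3)sc3ccccc23)c(OC)c1` gives 4100 nM. Compound 2 `COc1ccc(-c2c(C(=O)c3cc(OC)c(OC)c(OC)c3)sc3ccccc23)cc1C` gives > 10000 nM, which is a limit of the assay and not a number. Compound 3 `COc1ccc(Nc2c(C(=O)c3cc(OC)c(OC)c(OC)c3)sc3ccccc23)cc1` carries (4-methoxyphenyl)amino in place of 4-methoxy-3-methylphenyl on an aromatic carbon. Among the compounds with values here, the only measured step at this place, an at least 2.4-fold higher number from compound 1 to compound 2 (0.38 log units; beyond the scatter), is at least modest and involves no amino link, so it offers only a loose guide. A modest move toward a lower number in this assay is expected, though another limit remains possible. The expected change is an at least 2.5-fold lower number from compound 2 to compound 3 (0.39 log units; beyond the scatter). For compound 3 the estimate is 4000 nM, with an expected range of 500 nM to 10000 nM.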

Compound 3, half-maximal inhibitory concentration: 2900 nM
For compound 3 the middle estimate is 1.4-fold (0.14 log units) above the measured one, and the stated range covers the measured number.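

At this position, (4-methoxyphenyl)amino brings the series back inside the measurable range of this assay, with an at least 3.4-fold lower number from compound 2 to compound 3 (0.53 log units; beyond the scatter). The value of compound 2 is a limit of the assay and not a number: the limit of > 10000 nM in this assay, at which 1 of the 3 values shown sits. Set against 2,4-dimethoxyphenyl, the amino-linked ring gives no separation, with a 1.4-fold lower number from compound 1 to compound 3 (0.15 log units; within the scatter), so an amino link is tolerated here without a clear gain.

The step from compound 2 changes the link and drops the ring methyl together, and the two are not separated. Going by these compounds, a methylated amine or an ether oxygen as the link remains open, as does the role of the amine hydrogen.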